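This account rests on a few compounds, and the source may have more. Where it says the series, first, only, none or still open, it means among the compounds named here.

Measured so far in a functional assay on HL-60 cells (Homo sapiens) for cytotoxicity, read by WST assay, with a stated time of 48 h; a lower number here means a stronger inhibitor, a higher number a weaker inhibitor:

- compound 1, `COc1cc(C(c2ccc(O)c(OC)c2)[C@H](C)[C@H](C)CF)ccc1O`: 56000 nM
- compound 2, `COC[C@H](C(C)C)C(c1ccc(O)c(OC)c1)c1ccc(O)c(OC)c1`: 72000 nM
- compound 3, `COC[C@@H](C)[C@@H](C)C(c1ccc(O)c(OC)c1)c1ccc(O)c(OC)c1`: 85000 nM

Compound 3 gives the highest of the three numbers, but its gaps to compound 2 and to compound 1 both lie within the scatter, so the three measured compounds cannot be told apart on these data.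

Compound 4 is `CC[C@H](C(C)C)C(c1ccc(O)c(OC)c1)c1ccc(O)c(OC)c1`. Its difference from compound 3 is

1-isopropylpropyl in place of 2-(methoxymethyl)-1-methylpropyl on a saturated chain carbon bound to two aromatic carbons

All three measured steps concern the same saturated chain carbon bound to two aromatic carbons, and each was small: a 1.3-fold higher number from compound 1 to compound 2 (0.11 log units; within the scatter), a 1.5-fold higher number from compound 1 to compound 3 (0.18 log units; within the scatter), and a 1.2-fold higher number from compound 2 to compound 3 (0.07 log units; within the scatter). Among those steps the chain has been shortened, branched differently and had a fluoro swapped for a methoxy, and none of it moved the number beyond the scatter. Within the data shown here, no step on record removes the single hydrogen-bond acceptor of the chain altogether, as the change to compound 4 does, so that part of the change is untested.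

The expectation is therefore that compound 4 stays in the same range as compound 3, with a 1.1-fold higher number from compound 3 to compound 4 (0.02 log units; within the scatter) as the expected step, no larger than the scatter. The estimate for compound 4 in this assay is 90000 nM, with a range from 40000 nM to 200000 nM expected.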

Compound 4, half-maximal inhibitory concentration: 16000 nM
Compound 4: the middle estimate sits 5.6-fold (0.75 log units) above what was measured, outside the stated range (below it).
By their numbers in this assay, from the lowest: compound 4; then compounds 1, 2 and 3 (each within the scatter of the next).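

In this assay, this saturated chain carbon bound to two aromatic carbons proves sensitive to the nature of its chain, since the all-carbon 1-isopropylpropyl group, with no hydrogen-bond acceptor, gives a step beyond the scatter against 2-(methoxymethyl)-1-methylpropyl (a 5.3-fold lower number from compound 3 to compound 4 (0.73 log units; beyond the scatter)). The cleanest comparison is the replacement of methoxy by methyl, which leaves the chain otherwise unchanged (a 4.5-fold lower number from compound 2 to compound 4 (0.65 log units; beyond the scatter)), and the comparison with the fluorinated chain runs the same way (a 3.5-fold lower number from compound 1 to compound 4 (0.54 log units; beyond the scatter)), so among these four compounds only compound 4, the one without oxygen or fluorine in the chain, separates from the others. Nothing at hand accounts for this shift, and the link to the missing methoxy or fluoro rests on compound 4 alone.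

How far the trend runs along the chain remains open, as the compounds shown do not tell whether a longer chain such as n-butyl or n-pentyl at this carbon would lower the number further. They also leave open how an amine or a carboxylic acid at the chain end would compare with the all-carbon chain of compound 4.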